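This account rests on a few compounds, and the source may have more. Where it says the series, first, only, none or still open, it means among the compounds named here.

Measured compounds in a functional assay on U-251 cells (Homo sapiens) for antiproliferative activity, read by MTT assay, with a stated time of 24 h; on this read-out higher numbers stand for weaker inhibition and lower numbers for stronger inhibition:
- compound 1 `COc1ccc2c(=O)c(-c3cc(OC)c(OC)cc3OC)coc2c1`: 9400 nM
- compound 2 `COc1cc(OC)c(-c2coc3cc(OCc4ccccc4F)ccc3c2=O)cc1OC`: 2890 nM
- compound 3 `COc1cc(OC)c(-c2coc3cc(OCc4ccc([N+](=O)[O-])cc4)ccc3c2=O)cc1OC`: 9400 nM

On these numbers compound 3 stands level with compound 1, the two together at the high end of the three values; compound 2 is the only one set apart, with a 3.3-fold higher number from compound 2 to compound 3 (0.51 log units; beyond the scatter) running from it back to compound 3. The two steps from the unsubstituted parent also frame the picture: a 3.3-fold lower number from compound 1 to compound 2 (0.51 log units; beyond the scatter) is a modest gain, while no change at the digits printed from compound 1 to compound 3 (within the scatter) is no change at all.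

The unmeasured compound 4 `COc1cc(OC)c(-c2coc3cc(OCc4cccc(C(F)(F)F)c4)ccc3c2=O)cc1OC` differs from compound 3 in one place: 3-(trifluoromethyl)phenyl in place of 4-nitrophenyl on a saturated chain carbon bound to an oxygen on an aromatic ring.

Within the data shown here, the steps that bear on this are those in which the group on the saturated chain carbon bound to the oxygen on the aromatic ring is varied: the modest step of a 3.3-fold higher number from compound 2 to compound 3 (0.51 log units; beyond the scatter) and the flat step no change at the digits printed from compound 1 to compound 3 (within the scatter). They show that exchanging this group shifts the read-out by a modest amount at most. Neither of the measured groups is a trifluoromethyl-bearing phenyl, so the direction for compound 4 is not fixed; a modest improvement or no change beyond the scatter are both plausible. The estimate for compound 4 is therefore 4500 nM, with a range of 1500 nM to 13000 nM, which as a step means an expected 2.1-fold lower number from compound 3 to compound 4 (0.32 log units; beyond the scatter).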

Compound 4, half-maximal inhibitory concentration: > 10000 nM
Compound 4 was reported as a limit (the forecaster's own chance of this, stated with the estimate: 5%); middle value at least 2.2-fold (0.34 log units) away from the limit.
By their numbers in this assay, from the lowest: compound 2; then compounds 1 and 3 (each within the scatter of the next). At a limit, above all of these: compound 4.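

In this assay compound 4 stands only as a limit: the limit of > 10000 nM in this assay, at which 1 of the 4 values shown sits. Replacing 2-fluorophenyl with 3-(trifluoromethyl)phenyl gives an at least 3.4-fold higher number from compound 2 to compound 4 (0.53 log units; beyond the scatter), so the gain seen with a fluorine-bearing phenyl on the saturated chain carbon bound to an oxygen on an aromatic ring does not extend to every such group, and the group at this position can shift the number in either direction. Among these compounds, replacing hydrogen with 3-(trifluoromethyl)phenyl gives an at least 1.0-fold higher number from compound 1 to compound 4 (0.02 log units; that floor lies within the scatter), and replacing 4-nitrophenyl with it gives an at least 1.0-fold higher number from compound 3 to compound 4 (0.02 log units; that floor lies within the scatter); both floors lie within the scatter, so these two steps show no loss and leave compound 2 as the only compound of the four set apart from all the others.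

An unsubstituted phenyl or a 4-fluorophenyl on the same carbon would test whether the gain in compound 2 depends on the fluorine, on where it sits, or on the phenyl ring itself. Also open, from the compounds shown here alone, are the true size of the number for compound 4 and what a group carrying an amine or a carboxylic acid would do at this position.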